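Nitro to amino: the next step in the series

This account rests on a few compounds, and the source may have more. Where it says the series, first, only, none or still open, it means among the compounds named here.

Among the compounds with values here, in a functional assay (aorta) for inhibition, with Rattus norvegicus as the target, with a stated time of 8 days (a lower number here means a stronger inhibitor, a higher number a weaker inhibitor), compound 1 `Cc1nsc(-c2ccc(N3CCN(c4cccc(C(F)(F)F)c4)CC3)nn2)n1` gives 0.3 nM, and compound 2 `Cc1nsc(-c2ccc(N3CCN(c4cccc([N+](=O)[O-])c4)CC3)nn2)n1` gives 3 nM, the higher of the two numbers so far. Compound 3 `Cc1nsc(-c2ccc(N3CCN(c4cccc(N)c4)CC3)nn2)n1` is still unmeasured. It carries amino in place of nitro on an aromatic carbon, meta to a large group: amino in place of nitro on an aromatic carbon. Within the data shown here, one measured step bears on this change, a 10-fold higher number from compound 1 to compound 2 (1.00 log units; beyond the scatter), a modest step beyond the scatter that alters the group at the same place. It does not involve amino, and two values establish no trend, so the direction is tentative. A modest move towards a higher number in this assay is expected, somewhat smaller than that measured step, and a result within the scatter remains possible. The estimated step is a 3.3-fold higher number from compound 2 to compound 3 (0.52 log units; beyond the scatter). Compound 3 is expected at 10 nM, with an estimated range of 2 nM to 50 nM.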

Compound 3, half-maximal inhibitory concentration: > 100 nM
Compound 3 was reported as a limit (the forecaster's own chance of this, stated with the estimate: 5%); middle value at least 10-fold (1.00 log units) away from the limit.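

At this place on the ring the group matters far more than the first pair showed: in this assay, amino in place of nitro gives an at least 33-fold higher number from compound 2 to compound 3 (1.52 log units; beyond the scatter), a large step where trifluoromethyl to nitro was modest. Measured against the trifluoromethyl group, the change spans an at least 330-fold higher number from compound 1 to compound 3 (2.52 log units; beyond the scatter), so the three groups together cover a wide range at one position, with the amino group, which brings 1 hydrogen-bond donor where nitro has 0, at the high end. Compound 3 is reported as a limit and not as a number: the limit of > 100 nM in this assay, at which 1 of the 3 values shown sits.

Whether the donor count has anything to do with this step remains open, and the data give no cause for it. An acetamide or a dimethylamino group at the same place would test whether the loss holds for substituted nitrogen groups or only for the free amine.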